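Pyridin-2-yl for methylimidazole on the shared core

This account rests on a few compounds, and the source may have more. Where it says the series, first, only, none or still open, it means among the compounds named here.

In an ADME assay on microsomes (Mus musculus) for metabolic stability (a lower number here means slower removal, a higher number faster removal of the compound), compound 3 `CNC(=O)[C@@H]1CCCN1S(=O)(=O)c1ccc(Cl)c(COc2cccc3c(-c4nccn4C)cc(C)nc23)c1Cl` stands highest of the three measured compounds at 917 mL/min/kg, while compound 2 `CNC(=O)[C@@H]1CCCN1S(=O)(=O)c1ccc(Cl)c(COc2cccc3c(-c4cncn4C)cc(C)nc23)c1Cl` gives 117 mL/min/kg and compound 1 `Cc1cc(C(F)(F)F)c2cccc(OCc3c(Cl)ccc(S(=O)(=O)N4CCC[C@H]4C(=O)O)c3Cl)c2n1` gives 13.3 mL/min/kg. Compound 4 `CNC(=O)[C@@H]1CCCN1S(=O)(=O)c1ccc(Cl)c(COc2cccc3c(-c4ccccn4)cc(C)nc23)c1Cl` has pyridin-2-yl in place of 1-methyl-1H-imidazol-2-yl on an aromatic carbon, opposite the ring nitrogen: pyridin-2-yl in place of 1-methyl-1H-imidazol-2-yl on an aromatic carbon. For the measured compounds named here, one measured step bears on this change, a 7.8-fold higher number from compound 2 to compound 3 (0.89 log units; beyond the scatter), where only the attachment of the methylimidazole differs. Going by the values given here, no measured compound carries pyridin-2-yl, so the guide is weak, but a step of similar size is expected, and downward, since compound 3 tops the series. The expected move is a 3.1-fold lower number from compound 3 to compound 4 (0.49 log units; beyond the scatter). The estimate for compound 4 is 300 mL/min/kg, with an expected range of 100 mL/min/kg to 800 mL/min/kg.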

Compound 4, clearance: 733 mL/min/kg
Estimate against measurement, compound 4: 2.4-fold (0.39 log units) below, within the range that was stated.
By their numbers in this assay, from the lowest: compound 1; then compound 2; then compounds 4 and 3 (each within the scatter of the next).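

In this assay, the exchange at this position, opposite the ring nitrogen, gave a 1.3-fold lower number from compound 3 to compound 4 (0.10 log units; within the scatter), so pyridin-2-yl and 1-methyl-1H-imidazol-2-yl cannot be told apart here. Pyridin-2-yl also stands apart from the other methylimidazole, with a 6.3-fold higher number from compound 2 to compound 4 (0.80 log units; beyond the scatter), so among these three groups only 1-methyl-1H-imidazol-5-yl goes with the lower clearance. Nothing given here explains these numbers. From the compounds shown here alone, it remains open whether a phenyl ring or a morpholine at this position would fall with compound 2 or with compound 3 and compound 4.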